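Tolerability of a Methoxycarbonyl Analogue on Vero Cells

The source may report more compounds than this note shows. Statements on the series, on what has been measured and on what is new or still open speak of the compounds shown alone.

Measured so far:
Compound 1, `O=c1[nH]c(Nc2ccc(F)cc2)nc2cc(Cl)ccc12`: in an ADME assay on Vero cells (Chlorocebus sabaeus) for cytotoxicity, read by WST assay (a higher number here means that more compound is tolerated, a lower number that less compound is tolerated), compound 1 gives > 25000 nM, which is a limit of the assay and not a number.
Compound 2, `COc1cccc(Nc2nc3cc(Cl)ccc3c(=O)[nH]2)c1`: in this assay compound 2 gives > 25000 nM, again a limit of the assay rather than a number.

Where compound 2 stands is therefore set only by that limit. Both values shown sit at the same point, as the limit of > 25000 nM in this assay, at which 2 of the 2 values shown sit, records, so compound 2 cannot be placed above or below compound 1 on these numbers; the two compounds show the same limit and nothing more.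

Compound 3, `COC(=O)c1cccc(Nc2nc3cc(Cl)ccc3c(=O)[nH]2)c1`, differs from compound 2 in one place: methoxycarbonyl in place of methoxy on an aromatic carbon. Among the measured compounds shown here, no step between measured compounds is available to size this change. Because compound 2 sits at the limit of this assay recorded as > 25000 nM, the step is expected to be none beyond the scatter, in the sense that the limit is most likely reached again. For compound 3 the expected value in this assay is 25000 nM, within 12000 nM to 60000 nM. That expectation corresponds to a step of a number no higher from compound 2 to compound 3 (the limit leaves the size open).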

Compound 3, half-maximal cytotoxic concentration: > 25000 nM
Compound 3 gave a limit, no number; the forecaster's own chance of this, stated with the estimate: 80%; the middle value lies on the limit itself.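

No step can be read from compound 2 to compound 3, because both compounds sit at the same limit, which is not a number: the limit of > 25000 nM in this assay, at which 3 of the 3 values shown sit.

The compounds shown leave open whether methoxycarbonyl in place of methoxy on an aromatic carbon changes the outcome in this assay at all, and where any of the three compounds would reach its half-maximal cytotoxic concentration.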